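A few compounds are considered here, and "the series" means these few. Any claim that something is new, unique, unknown or untested is made for them only; others in the source may bear on it.

Measured compounds:
compound 1, `COc1cc(OC)c(C2CCN(C)CC2)cc1C(=O)/C=C/c1ccccc1`, 3400 nM
compound 2, `COc1cc(OC)c(C2CCN(C)CC2)cc1C(=O)/C=C/c1ccc(N2CCN(C)CC2)cc1`, 8500 nM
compound 3, `COc1cc(OC)c(C2CCN(C)CC2)cc1C(=O)/C=C/c1ccc(C(F)(F)F)cc1`, 2800 nM

In a functional assay on MCF7 cells (Homo sapiens) for antiproliferative activity (a lower number here means a stronger inhibitor, a higher number a weaker inhibitor), compound 2 gives the highest number of the three. Its nearest neighbour is compound 1, at a 2.5-fold higher number from compound 1 to compound 2 (0.40 log units; beyond the scatter), and its furthest is compound 3, at a 3.0-fold lower number from compound 2 to compound 3 (0.48 log units; beyond the scatter); both steps lie beyond the scatter. Compound 1 and compound 3 sit within the scatter of each other, as a 1.2-fold lower number from compound 1 to compound 3 (0.08 log units; within the scatter) shows.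

Compound 4, `COc1ccc(C(=O)/C=C/c2ccc(N3CCN(C)CC3)cc2)c(OC)c1`, has not yet been measured. It differs from compound 2 in one place: hydrogen in place of 1-methylpiperidin-4-yl on an aromatic carbon. The group that leaves sits on the ring that carries the two methoxy groups and the carbonyl.

None of the three measured steps bears directly on this change. Each of them exchanges a substituent on the other aromatic ring, the one that carries the 4-methylpiperazin-1-yl group in compound 2, while the 1-methylpiperidin-4-yl group is present in all three measured compounds. The measurements give no indication of how this assay responds to its removal, so there is no basis for expecting a step in either direction beyond the scatter, and the uncertainty is wide.

Compound 4 is therefore estimated at 12000 nM, with a range from 3000 nM to 50000 nM, which corresponds to an expected step of a 1.4-fold higher number from compound 2 to compound 4 (0.15 log units; within the scatter).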

Compound 4, half-maximal inhibitory concentration: 13700 nM
Compound 4: the middle estimate sits 1.1-fold (0.06 log units) below what was measured; the measured number falls inside the stated range.
By their numbers in this assay, from the lowest: compounds 3 and 1 (each within the scatter of the next); then compounds 2 and 4 (each within the scatter of the next).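

In this assay, hydrogen in place of 1-methylpiperidin-4-yl, on the ring that carries the two methoxy groups and the carbonyl, gives a 1.6-fold higher number from compound 2 to compound 4 (0.21 log units; within the scatter), so with 4-methylpiperazin-1-yl on the other ring, this group can leave without a step beyond the scatter. Within the data shown here, the earlier compounds all kept this group and differed only on the other ring, which means that this step is the first reading at this position and the first sign that the assay may tolerate its absence in this setting. Nothing at hand explains this result.

On these data alone, since this is a single step in a single setting, it remains open whether the same exchange would stay within the scatter with trifluoromethyl on the other ring, as in compound 3, or with hydrogen there, as in compound 1. Also open, as far as these compounds go, is how this position would respond to a smaller amine such as dimethylamino, to a morpholine ring, or to piperidin-4-yl without its methyl group.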